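A few compounds are considered here, and "the series" means these few. Any claim that something is new, unique, unknown or untested is made for them only; others in the source may bear on it.

Measured so far in a functional assay on MCF7 cells (Homo sapiens) for antiproliferative activity; on this read-out lower numbers stand for stronger inhibition of growth and higher numbers for weaker inhibition of growth:
compound 1, `Cc1cc(-c2nc3ccccc3s2)ccc1N` — < 0.1 nM (a limit)
compound 2, `Oc1ccc(-c2nc3ccccc3s2)cc1O` — 2190 nM
compound 3, `COc1ccc(-c2nc3cc(F)ccc3s2)cc1Cl` — 760 nM

In this assay compound 3 holds the lowest of the two numbers; compound 2 sits above it, beyond the scatter. The value of compound 1 is an assay limit and not a number (the limit of < 0.1 nM in this assay, at which 1 of the 3 values shown sits).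

Compound 4, `COc1ccc(-c2nc3cc(F)ccc3s2)cc1O`, is not yet measured. It differs from compound 3 by hydroxy in place of chloro on an aromatic carbon. Compound 2 also carries hydroxy groups and gives 2190 nM, the weaker of the two numbers, so the step is expected to go toward weaker inhibition: the expected step of a 2.1-fold higher number from compound 3 to compound 4 (0.32 log units; beyond the scatter) is a moderate one, beyond the scatter. Compound 4 is estimated at 1600 nM, between 450 nM and 6000 nM.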

Compound 4, concentration for 50% growth inhibition: 500 nM
Beside the measured number, compound 4's estimate is 3.2-fold (0.51 log units) above it; low and high end bracket the measured number.
By their numbers in this assay, from the lowest: compounds 4 and 3 (each within the scatter of the next); then compound 2. At a limit, below all of these: compound 1.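

Hydroxy in place of chloro, ortho to a methoxy group, gives the first single-place step of the series in this assay: a 1.5-fold lower number from compound 3 to compound 4 (0.18 log units; within the scatter). This position therefore accepts a hydrogen-bond donor in place of chloro with no change beyond the scatter. Nothing measured here bears on why the two groups read alike:.

The compounds shown leave open whether a carboxylic acid or an ethoxy group at this position would also stay within the scatter. They also leave open whether the same swap reads alike without the neighbouring methoxy group.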